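Replacing a ring on the amide with an open chain

The compounds below may be only part of what the source reports. "The series", "measured", "known", "first", "only" and "open" are said of these compounds alone.

Three compounds of one series have been measured in an assay on HEK293 cells for displacement of a labelled ligand from NPC1-like intracellular cholesterol transporter 1 (Homo sapiens); a higher number here means a weaker inhibitor, a lower number a stronger inhibitor:
compound 1, `CC(C)(C)c1ccc(C(=O)N2CCC3(CC2)C(=O)N(CC(=O)N2CCCC(C(N)=O)C2)CN3c2ccccc2)cc1`, gives 16900 nM;
compound 2, `CCC1CCCN(C(=O)CN2CN(c3ccccc3)C3(CCN(C(=O)c4ccc(C(C)(C)C)cc4)CC3)C2=O)C1`, gives 3900 nM;
compound 3, `CC(C)(C)c1ccc(C(=O)N2CCC3(CC2)C(=O)N(CC(=O)N2CCCC(O)C2)CN3c2ccccc2)cc1`, gives 12200 nM.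

Compound 3 holds the second highest of the three numbers. It sits close to compound 1, as a 1.4-fold lower number from compound 1 to compound 3 (0.14 log units; within the scatter) shows, and further from compound 2, as a 3.1-fold higher number from compound 2 to compound 3 (0.50 log units; beyond the scatter) shows.

Compound 4, `CC(C)(C)OC(=O)NCCCNC(=O)CN1CN(c2ccccc2)C2(CCN(C(=O)c3ccc(C(C)(C)C)cc3)CC2)C1=O`, differs from compound 3 in one place: (3-((tert-butoxycarbonyl)amino)propyl)amino in place of 3-hydroxypiperidin-1-yl on a carbonyl carbon.

All three measured steps concern only the group carried on the saturated ring that compound 4 no longer has: a 4.3-fold lower number from compound 1 to compound 2 (0.64 log units; beyond the scatter), a 1.4-fold lower number from compound 1 to compound 3 (0.14 log units; within the scatter) and a 3.1-fold higher number from compound 2 to compound 3 (0.50 log units; beyond the scatter). They show that the amide end of the molecule tolerates changes with at most modest movement in the numbers, but none of them opens the ring or adds a chain of this length, so they bear only loosely on the present change. On that basis the step from compound 3 to compound 4 is expected to stay within the scatter, a 1.2-fold lower number from compound 3 to compound 4 (0.09 log units; within the scatter), with wide uncertainty. Compound 4 is therefore estimated at 10000 nM, in a range from 3000 nM to 40000 nM.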

Compound 4, half-maximal inhibitory concentration: 4500 nM
For compound 4 the middle estimate is 2.2-fold (0.35 log units) above the measured one; the range from low to high includes it.
By their numbers in this assay, from the lowest: compounds 2 and 4 (each within the scatter of the next); then compounds 3 and 1 (each within the scatter of the next).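

The six-membered ring on the carbonyl carbon is not required for binding in this assay: the open chain (3-((tert-butoxycarbonyl)amino)propyl)amino, which has no ring, gives a 2.7-fold lower number from compound 3 to compound 4 (0.43 log units; beyond the scatter) when it replaces 3-hydroxypiperidin-1-yl and a 3.8-fold lower number from compound 1 to compound 4 (0.57 log units; beyond the scatter) when it replaces 3-carbamoylpiperidin-1-yl. Set against 3-ethylpiperidin-1-yl, the same chain gives a 1.2-fold higher number from compound 2 to compound 4 (0.06 log units; within the scatter), so this position accepts a ring or a much larger open chain with no difference that can be read between those two compounds. Nothing measured here gives a reason for any of these steps.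

The change removes the ring, lengthens the group and adds a tert-butoxycarbonyl end all at once, so these compounds cannot show which of those features accounts for the lower number relative to compound 3 and compound 1. A free primary amine at the end of the propyl chain, or a simple butyl chain on the amide nitrogen, would test whether the tert-butoxycarbonyl group is needed at all.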